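Methyl on the pyrazole-side phenyl of compound 1

The compounds below may be only part of what the source reports. "The series", "measured", "known", "first", "only" and "open" are said of these compounds alone.

Compound 1 `Nc1cc(-c2ccc(Cl)cc2)nc2cc(-c3ccccc3)nn12` is one of two compounds tested in a functional assay on the whole organism (strain Wistar) for inhibition, with Rattus norvegicus as the target, read by paw edema, with stated times of 30 min and 1 h, at a dose of 50 mg/kg by the oral route; a lower number here means less inhibition, a higher number more inhibition at the dose given (going by the name of the read-out). In this assay compound 1 gives 21.2%, the lowest of the two numbers shown. Its nearest neighbour is compound 2 `Cc1ccc(-c2cc(N)n3nc(-c4ccccc4)cc3n2)cc1`, which in this assay gives 28.8%; the step of a number 7.6 percentage points higher from compound 1 to compound 2 (within the scatter) arises from methyl in place of chloro on an aromatic carbon and lies within the scatter.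

Compound 3 `Cc1ccc(-c2cc3nc(-c4ccc(Cl)cc4)cc(N)n3n2)cc1` has not yet been measured in this assay. It differs from compound 1 by methyl in place of hydrogen on an aromatic carbon. Going by the values given here, the only measured step, that from compound 1 to compound 2, also swaps a small group on a phenyl ring and produced no change beyond the scatter, so a step of similar size is expected here, with no clear direction. Compound 3 is therefore estimated at 25%, in the range 10% to 40%, which means an expected step of a number 3.8 percentage points higher from compound 1 to compound 3 (within the scatter).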

Compound 3, a percentage reported as inhibition, in the whole organism at one dose (the size of the read-out at that dose, not a potency): 59.6%
The estimate for compound 3 lay 34.6 percentage points below the measured number; the whole stated range lies below it.
By their numbers in this assay, from the lowest: compounds 1 and 2 (each within the scatter of the next); then compound 3.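

In this assay the ring that goes from phenyl to 4-methylphenyl proves sensitive to substitution, with a number 38.4 percentage points higher from compound 1 to compound 3 (beyond the scatter) for methyl in place of hydrogen, a large step from a single added carbon. Going by these compounds alone, the only earlier step, a number 7.6 percentage points higher from compound 1 to compound 2 (within the scatter), came from exchanging chloro for methyl on the other phenyl ring and gave no sign that a small group could change the read-out this much. Nothing shown here bears on why methyl at this place has this effect.

The compounds shown leave open whether an ethyl group, a methoxy group or an amine at the same place would keep, raise or lose this gain. They also leave open whether the gain from methyl holds when the chloro on the other ring is replaced, and how it would look at other doses.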